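The compounds below may be only part of what the source reports. "The series", "measured", "known", "first", "only" and "open" are said of these compounds alone.

Of the compounds shown here, three sharing one core have been tested so far in an assay (Cricetulus griseus) for inhibition of aldehyde dehydrogenase, mitochondrial (Homo sapiens); on this read-out lower numbers stand for stronger inhibition and higher numbers for weaker inhibition. Compound 1 `O=C(O)CCCCOc1ccc2c(=O)c(-c3ccc(O)cc3)coc2c1` gives 100 nM, the lowest of the two numbers shown. Compound 2 `CCOC(=O)CCCCCOc1ccc2c(=O)c(-c3ccc(O)cc3)coc2c1` gives 280 nM in this assay, so the step of a 2.8-fold higher number from compound 1 to compound 2 (0.45 log units; beyond the scatter) is modest but real. Compound 3 `CCCCCCCCCCCCOc1ccc2c(=O)c(-c3ccc(O)cc3)coc2c1` reaches only the limit of this assay, > 9000 nM, and no number is known for it (the limit of > 9000 nM in this assay, at which 1 of the 3 values shown sits). The step of an at least 90-fold higher number from compound 1 to compound 3 (1.95 log units; beyond the scatter) is therefore large, and so is an at least 32-fold higher number from compound 2 to compound 3 (1.50 log units; beyond the scatter).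

Compound 4 `CC(C)Oc1ccc2c(=O)c(-c3ccc(O)cc3)coc2c1` has not yet been measured. Its single difference from compound 1 is this: isopropyl in place of 4-carboxybutyl on an oxygen on an aromatic ring

Both measured steps from compound 1 bear on this change. Masking the carboxy as an ester cost a modest amount, while replacing the whole carboxy-bearing chain with a long chain removed measurable inhibition. Compound 4 likewise loses the carboxy, though it gains no long chain. A large upward step in this assay, clearly beyond the scatter, is therefore expected, though smaller than for compound 3. The step of a 20-fold higher number from compound 1 to compound 4 (1.30 log units; beyond the scatter) is the estimate made here. Compound 4 is expected to give about 2000 nM, with a range from 400 nM to 9000 nM.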

Compound 4, half-maximal inhibitory concentration: 80 nM
Beside the measured number, compound 4's estimate is 25-fold (1.40 log units) above it; the measured number lies below the stated range.
By their numbers in this assay, from the lowest: compounds 4 and 1 (each within the scatter of the next); then compound 2. At a limit, above all of these: compound 3.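

In this assay the exchange of 4-carboxybutoxy for isopropoxy appears as a 1.3-fold lower number from compound 1 to compound 4 (0.10 log units; within the scatter), so a much shorter group with no carboxy on this oxygen on the aromatic ring leaves the read-out unchanged within the usual scatter. Inhibition at this level therefore does not depend on a carboxy group at this position, and losing the carboxy cannot by itself account for the weak result of compound 3, whose long chain sets it apart from compound 4. Compound 3 remains the only one of these compounds that gives a limit rather than a number: the limit of > 9000 nM in this assay, at which 1 of the 4 values shown sits.

On these data alone, it remains open how long a plain carbon chain on this oxygen can grow before inhibition fades, since a butyl or hexyl chain would fall in the wide gap between isopropyl and the long chain of compound 3. Also unresolved is whether this position accepts other kinds of group, such as an amine at the end of a chain, or whether a methyl or a free hydroxy at this place would serve equally well.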